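The source may hold more compounds than are shown below. What is called first, only, known or untested is meant among the compounds shown, and "the series" means these compounds.

Of the compounds shown here, two of a shared core have been measured in a functional assay on MCF7 cells (Homo sapiens) for cytotoxicity, read by sulforhodamine B assay; a higher number here means a weaker inhibitor of growth, a lower number a stronger inhibitor of growth. Compound 1 `CC1=CC[C@@H]([C@@](C)(O)CCCC(C)(C)NC(=S)N/N=C\c2ccc(C)cc2)CC1` carries a 4-methylphenyl group on the carbon with a double bond to nitrogen, and in this assay compound 1 gives 7230 nM. Compound 2 `CC1=CC[C@@H]([C@@](C)(O)CCCC(C)(C)NC(=S)N/N=C\c2ccccc2[N+](=O)[O-])CC1` carries a 2-nitrophenyl group in the same place, and in this assay compound 2 gives 18600 nM. That exchange produced a 2.6-fold higher number from compound 1 to compound 2 (0.41 log units; beyond the scatter), so compound 2 stands with the highest number of the two, that is, as the weaker inhibitor of growth.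

Compound 3 `CC1=CC[C@@H]([C@@](C)(O)CCCC(C)(C)NC(=S)N/N=C\c2ccccc2Cl)CC1` differs from compound 2 in one place: chloro in place of nitro on an aromatic carbon. Within the data shown here, the only measured step, the one from compound 1 to compound 2, swapped a group at a different position of the ring and a different kind of group, so it bears on this change only loosely; it shows that a change on this ring can move the number by a modest amount. A modest step in this assay toward a lower number is therefore expected, roughly a 1.6-fold lower number from compound 2 to compound 3 (0.19 log units; within the scatter). Compound 3 is estimated at 12000 nM, within a range from 5000 nM to 30000 nM.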

Compound 3, concentration for 50% growth inhibition: 31200 nM
Compound 3: the middle estimate sits 2.6-fold (0.41 log units) below what was measured, and the stated range ends below it.
By their numbers in this assay, from the lowest: compound 1; then compounds 2 and 3 (each within the scatter of the next).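

Exchanging the nitro group, with its three heavy atoms, for a single chlorine atom on this aromatic carbon gives a 1.7-fold higher number from compound 2 to compound 3 (0.22 log units; within the scatter) in this assay and so the assay does not tell these two groups apart at this place. With a 2.6-fold higher number from compound 1 to compound 2 (0.41 log units; beyond the scatter) and a 4.3-fold higher number from compound 1 to compound 3 (0.64 log units; beyond the scatter) now both printed as beyond the scatter, the 2-nitrophenyl and 2-chlorophenyl compounds share a side, and compound 1 with its 4-methylphenyl group is the stronger inhibitor of growth against each of them. No measurement available here explains either the likeness of the two groups or the gap to compound 1.

Compound 1 differs from compound 2 and compound 3 both in the kind of group and in where that group sits on the ring, so these steps cannot say which of the two matters. A 2-methylphenyl or a 4-chlorophenyl group would separate those two questions, while an amine or a methoxy group at the place of the chloro would show whether a quite different group also stays within the scatter of these two.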